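This account rests on a few compounds, and the source may have more. Where it says the series, first, only, none or still open, it means among the compounds named here.

Working notes on the series. The three measured compounds share one core and differ in the two aryl or alkyl groups on it: compound 1 `CCCc1n[nH]c2c(=O)n(NC(=O)c3ccncc3)c(-c3cccc(OC)c3)nc12`, compound 2 `O=C(Nn1c(-c2cccc([N+](=O)[O-])c2)nc2c(-c3ccc(Cl)cc3)n[nH]c2c1=O)c1cccnc1` and compound 3 `COc1cccc(-c2nc3c(-c4ccco4)n[nH]c3c(=O)n2NC(=O)c2cccnc2)c1`. In a functional assay on SK-OV-3 cells (Homo sapiens) for cytotoxicity, read by sulforhodamine B assay, with a stated time of 2 days, tested at 100 uM (a lower number here means less inhibition, a higher number more inhibition at the concentration tested (going by the name of the read-out)), compound 1 gives 4.04%, compound 2 gives 30.2% and compound 3 gives 25%. Compound 2 holds the highest of the three numbers, but compound 3 lies within the scatter of it; only compound 1 sits beyond the scatter, below compound 2.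

The unmeasured compound 4 `O=C(Nn1c(-c2cccc([N+](=O)[O-])c2)nc2c(CCc3ccccc3)n[nH]c2c1=O)c1cccnc1` follows from compound 2 by one change: phenethyl in place of 4-chlorophenyl on an aromatic carbon. For the measured compounds named here, no measured pair isolates this change, so the expectation rests on the wider comparison. Compound 1, which carries a chain rather than an aromatic ring at the same position, gives the low reading of 4.04% in this assay, whereas the two aryl-bearing compounds read higher. A downward step of a number 12.2 percentage points lower from compound 2 to compound 4 (beyond the scatter) is therefore expected, modest and near the edge of the scatter. Compound 4 is estimated at 18%, within 4% to 34%.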

Compound 4, a percentage reported as inhibition, at one concentration (the size of the read-out at that concentration, not a potency): 30.2%
The estimate for compound 4 lay 12.2 percentage points below the measured number, within the range that was stated.
By their numbers in this assay, from the lowest: compound 1; then compounds 3, 2 and 4 (each within the scatter of the next).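

In this assay, for the compounds shown here, the exchange of 4-chlorophenyl for phenethyl on this aromatic carbon gives no change at the digits printed from compound 2 to compound 4 (within the scatter), and this is the first measured pair to isolate a change at this position. With the rest of compound 2 held fixed, the reading therefore does not depend on the chlorine, nor on the six-membered aromatic ring being attached directly to the core. Nothing available accounts for this result.

As far as these compounds go, it remains open whether a longer chain such as phenylpropyl, or a carboxylic acid or an amine on the phenyl ring of phenethyl, would leave the reading in place. As each reading comes from a single concentration, the compounds shown also leave open whether compound 2 and compound 4 would match in potency.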